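Trading the Aryl Ring for a Methyl Group

This account rests on a few compounds, and the source may have more. Where it says the series, first, only, none or still open, it means among the compounds named here.

Of the compounds shown here, three sharing one core have been tested in a functional assay on NB-4 cells (Homo sapiens) for cytotoxicity, read by CCK-8 assay, with a stated time of 24 h; on this read-out higher numbers stand for weaker inhibition and lower numbers for stronger inhibition. Compound 1 `C=CC(=O)N1C(=O)CC(c2ccc([N+](=O)[O-])cc2)Sc2ccccc21` gives 37700 nM. Compound 2 `C=CC(=O)N1C(=O)CC(c2ccc(C)cc2)Sc2ccccc21` gives 37300 nM, and compound 3 `C=CC(=O)N1C(=O)CC(c2ccccc2Cl)Sc2ccccc21` gives 33800 nM. Compound 2 stands second highest of these three numbers, though all three sit within the scatter of one another: the step of a 1.0-fold lower number from compound 1 to compound 2 (0.00 log units; within the scatter) and the step of a 1.1-fold lower number from compound 2 to compound 3 (0.04 log units; within the scatter) are each too small to count as a change. Compound 4 `C=CC(=O)N1C(=O)CC(C)Sc2ccccc21` has not yet been measured. It differs from compound 2 in one place: methyl in place of 4-methylphenyl on a saturated ring carbon. Neither measured step bears directly on this change; both swap one aryl group for another or alter a substituent on it, and both stayed within the scatter. That offers little ground to expect a shift, but removing the whole ring is a larger alteration than anything seen so far, so the range is kept wide. Compound 4 is expected to give 45000 nM, with a range from 20000 nM to 120000 nM. This estimate means a step of a 1.2-fold higher number from compound 2 to compound 4 (0.08 log units; within the scatter), expected to fall close to the scatter.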

Compound 4, half-maximal inhibitory concentration: 227000 nM
For compound 4 the middle estimate is 5.0-fold (0.70 log units) below the measured one, outside the stated range (above it).
By their numbers in this assay, from the lowest: compounds 3, 2 and 1 (each within the scatter of the next); then compound 4.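

The earlier swaps of one aryl group for another stayed within the scatter in this assay, but removing the ring altogether does not: methyl in place of 4-methylphenyl gives (a 6.1-fold higher number from compound 2 to compound 4 (0.78 log units; beyond the scatter)), and methyl in place of 2-chlorophenyl gives (a 6.7-fold higher number from compound 3 to compound 4 (0.83 log units; beyond the scatter)). On this saturated ring carbon next to the ring sulfur, then, compound 2 and compound 3, each with an aromatic ring there, show stronger inhibition than compound 4 with its methyl, while the rest of the shared core stays the same. Nothing available here explains why the ring makes this difference.

The compounds shown leave open whether the ring must be aromatic, which a cyclohexyl group at this carbon would test. On these data alone, what a benzyl group, an amine or a longer chain would do there also remains open.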